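This account rests on a few compounds, and the source may have more. Where it says the series, first, only, none or still open, it means among the compounds named here.

In an ADME assay on microsomes from liver (Homo sapiens) for metabolic stability, read by LC-MS, tested at 1 mM (a lower number here means that the compound disappears faster, a higher number that the compound lasts longer), compound 1 `N#Cc1ccc(F)cc1Cn1c(N2CCC[C@@H](N)C2)nc2cc[nH]c2c1=O` gives 3.33 h. Compound 2 `N#Cc1ccc(F)cc1Cn1c(N2CCC[C@@H](N)C2)nc2c(-c3ccsc3)c[nH]c2c1=O`, which carries thiophen-3-yl on the same core, gives 2.67 h, so the two stand within the scatter of each other. Compound 3 `CS(=O)(=O)c1ccc(-c2c[nH]c3c(=O)n(Cc4cc(F)ccc4C#N)c(N4CCC[C@@H](N)C4)nc23)cc1F` has not yet been measured. It differs from compound 2 in one place: 3-fluoro-4-(methylsulfonyl)phenyl in place of thiophen-3-yl on an aromatic carbon. In words, it has 3-fluoro-4-(methylsulfonyl)phenyl in place of thiophen-3-yl on an aromatic carbon of a five-membered aromatic ring with 1 nitrogen. For the measured compounds named here, only one measured step bears on this place: a 1.2-fold lower number from compound 1 to compound 2 (0.10 log units; within the scatter), with thiophen-3-yl in place of hydrogen. Going by the values given here, no measured compound carries the entering group, so this step is an indirect guide. Among the compounds with values here, with a 1.2-fold lower number from compound 1 to compound 2 (0.10 log units; within the scatter) as the only evidence at this place, no change beyond the scatter is expected in this assay. The expected step is a 1.1-fold lower number from compound 2 to compound 3 (0.03 log units; within the scatter). For compound 3 the estimated half-life is 2.5 h, with an expected range from 1.3 h to 4.8 h.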

Compound 3, half-life: > 3.33 h
Compound 3: a limit, no number; the forecaster's own chance of this, stated with the estimate: 10%; middle value at least 1.3-fold (0.12 log units) away from the limit.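

Compound 3 gives a limit in this assay, not a number: the limit of > 3.33 h in this assay, at which 1 of the 3 values shown sits.

On this aromatic carbon of the five-membered aromatic ring, 3-fluoro-4-(methylsulfonyl)phenyl in place of thiophen-3-yl gives an at least 1.2-fold higher number from compound 2 to compound 3 (0.09 log units; that floor lies within the scatter), and 3-fluoro-4-(methylsulfonyl)phenyl in place of hydrogen on this carbon gives a number no lower from compound 1 to compound 3 (the limit leaves the size open), a step whose size cannot be read. The earlier compounds had shown only thiophen-3-yl here, whereas this result adds a six-membered aromatic ring of carbon only, with 11 heavy atoms in place of 5, and the half-life shows no fall. Going by these compounds, how far the half-life of compound 3 actually reaches remains unknown, and the floor of the step lies within the scatter, so this result shows tolerance of the larger group in this assay and not a gain.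

The compounds shown leave open whether the fluorine or the methylsulfonyl group matters for this reading, which a plain phenyl or a phenyl carrying only one of the two would separate. They also leave open how this position behaves with an amine or a carboxylic acid on that ring.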